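Ethoxy to Methoxy Trim in the Acid Series

A few compounds are considered here, and "the series" means these few. Any claim that something is new, unique, unknown or untested is made for them only; others in the source may bear on it.

Compound 1 `CCOc1cc2[nH]c(Cc3nn(CC(=O)O)c(=O)c4ccccc34)nc2cc1Cl` gives 17 nM in a functional assay on CHO cells for antagonist activity at sphingosine 1-phosphate receptor 2 (Homo sapiens), read by calcium flux; on this read-out higher numbers stand for weaker inhibition and lower numbers for stronger inhibition. Compound 2 `O=C(O)Cc1nn(Cc2cn3cc(OCC4CC4)c(Cl)cc3n2)c2ccccc2c1=O` gives 20 nM in this assay, and compound 3 `C[C@H](C(=O)O)c1nn(Cc2cn3cc(OCC4CC4)c(Cl)cc3n2)c2ccccc2c1=O` gives 3.2 nM in this assay. The one measured methyl removal, (hydrogen in place of methyl on a saturated chain carbon bound to an aromatic carbon and a carbonyl carbon), gave a 6.3-fold higher number from compound 3 to compound 2 (0.80 log units; beyond the scatter). Compound 4 `COc1cc2[nH]c(Cc3nn(CC(=O)O)c(=O)c4ccccc34)nc2cc1Cl` carries the same kind of change on compound 1, (hydrogen in place of methyl on a saturated chain carbon bound to an oxygen on an aromatic ring), though the place differs: a saturated chain carbon bound to an oxygen on an aromatic ring, not one bound to an aromatic carbon and a carbonyl carbon. The difference between the core of compound 1 and the core of compound 3 is not broken down here. The measured step was made at a different place, so it serves only as a rough guide. A step of a 1.8-fold higher number from compound 1 to compound 4 (0.25 log units; within the scatter) is expected from compound 1 to compound 4, smaller than the measured one. Compound 4 is therefore expected near 30 nM, likely between 10 nM and 100 nM.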

Compound 4, half-maximal inhibitory concentration: 61 nM
The estimate for compound 4 lay 2.0-fold (0.31 log units) below the measured number; measured number inside the range.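

In this assay, trimming ethoxy to methoxy gives a 3.6-fold higher number from compound 1 to compound 4 (0.55 log units; beyond the scatter). Removing a methyl raises the number on both cores, and the two steps do not differ beyond the scatter: the same change on two cores in this assay, a 6.3-fold higher number (0.80 log units; beyond the scatter) from compound 3 to compound 2 and a 3.6-fold higher number (0.55 log units; beyond the scatter) from compound 1 to compound 4, 1.7-fold (0.24 log units) apart, within the scatter of two such steps. This agreement covers direction and rough size only; the two removals sit at different places, so it does not show that a step at one place carries over to the other, or that either step would hold on the other core.

Open, on these data alone, is how a longer chain such as propoxy, or an amine, would read in place of ethoxy on the core of compound 1. With only ethoxy and methoxy compared at this place, no trend with chain length can be drawn.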